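A few compounds are considered here, and "the series" means these few. Any claim that something is new, unique, unknown or untested is made for them only; others in the source may bear on it.

Three compounds share one core and differ only in the amine bound to the thiocarbonyl group: compound 1 `CC1CCCCN1C(=S)SCc1ccc(C(=O)Nc2ccccc2N)cc1`, compound 2 `Cc1ccc(N2CCN(C(=S)SCc3ccc(C(=O)Nc4ccccc4N)cc3)CC2)cc1` and compound 3 `Nc1ccccc1NC(=O)c1ccc(CSC(=S)N2CCc3ccc([N+](=O)[O-])cc32)cc1`. In a functional assay on HeLa cells (Homo sapiens) for antiproliferative activity, read by CCK-8 assay, with a stated time of 72 h, tested at 8 uM (on this read-out lower numbers stand for a weaker effect and higher numbers for a stronger effect at the one concentration tested), compound 1 gives 76.3%, compound 3 gives 62.1%, and compound 2 gives 24%, the lowest of the three numbers, below compound 3 and compound 1 by margins beyond the scatter. Compound 4 `Nc1ccccc1NC(=O)c1ccc(CSC(=S)N2CCN(Cc3ccccc3)CC2)cc1` has not been measured in this assay; its change from compound 2 is benzyl in place of 4-methylphenyl on an amine nitrogen in a ring. Within the data shown here, no measured pair shows this exact change, so the size of the step is open. Given that the other two amines sit well above compound 2, compound 4 is expected to give 45%, between 20% and 72%, an expected rise of a number 21 percentage points higher from compound 2 to compound 4 (beyond the scatter).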

Compound 4, a percentage reported as inhibition, at one concentration (the size of the read-out at that concentration, not a potency): 31.3%
Estimate against measurement, compound 4: 13.7 percentage points above; measured number inside the range.
By their numbers in this assay, from the lowest: compounds 2 and 4 (each within the scatter of the next); then compound 3; then compound 1.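

Putting benzyl in place of 4-methylphenyl on the amine nitrogen in the ring gives, in this assay, a number 7.3 percentage points higher from compound 2 to compound 4 (within the scatter). The two compounds hold the same atoms, joined differently, and this read-out does not tell them apart, so at this position the change shows no effect larger than the scatter. Nothing given here explains the result. Going by these compounds, it remains open whether a longer chain such as phenylethyl, or an acetyl group, in place of benzyl would give a number beyond the scatter from compound 4.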